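This account rests on a few compounds, and the source may have more. Where it says the series, first, only, none or still open, it means among the compounds named here.

The series shares the core of compound 1 `O=C(O)CCn1cc(Cc2ccc(F)cc2)c2cc(NS(=O)(=O)c3ccc(F)cc3)ccc21` and, among the measured compounds, varies only the sulfonamide aryl substituent. In a functional assay on aorta for antagonist activity at thromboxane A2 receptor (Rattus norvegicus) (on this read-out higher numbers stand for weaker binding and lower numbers for tighter binding), compound 1 gives 0.479 nM, the second highest of the three numbers. Compound 2 `O=C(O)CCn1cc(Cc2ccc(F)cc2)c2cc(NS(=O)(=O)c3ccc(Cl)cc3)ccc21` gives 0.234 nM and compound 3 `O=C(O)CCn1cc(Cc2ccc(F)cc2)c2cc(NS(=O)(=O)c3ccccc3)ccc21` gives 0.676 nM. The measured steps of a 2.0-fold lower number from compound 1 to compound 2 (0.31 log units; beyond the scatter), a 1.4-fold higher number from compound 1 to compound 3 (0.15 log units; within the scatter) and a 2.9-fold higher number from compound 2 to compound 3 (0.46 log units; beyond the scatter) all sit on that aryl ring. Compound 4 `O=C(O)CCn1ccc2cc(NS(=O)(=O)c3ccc(F)cc3)ccc21` changes a different part of the molecule: hydrogen in place of 4-fluorobenzyl on an aromatic carbon. Among the measured compounds shown here, no measured step touches this position, so nothing measured bears directly on it. Removing a group of that size is expected to raise the number in this assay beyond the scatter, with wide uncertainty, and the expected step is a 10-fold higher number from compound 1 to compound 4 (1.02 log units; beyond the scatter). Compound 4 is therefore estimated at 5 nM, within a range from 1 nM to 30 nM.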

Compound 4, dissociation constant: 3.72 nM
Estimate against measurement, compound 4: 1.3-fold (0.13 log units) above; measured number inside the range.
By their numbers in this assay, from the lowest: compound 2; then compounds 1 and 3 (each within the scatter of the next); then compound 4.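

Hydrogen in place of 4-fluorobenzyl gives a 7.8-fold higher number from compound 1 to compound 4 (0.89 log units; beyond the scatter) in this assay, a larger step than any measured on the sulfonamide aryl ring. The position therefore affects this read-out, although compound 4, without the group, still gives 3.72 nM. No available evidence accounts for this step.

As far as these compounds go, whether the fluorine, the aromatic ring or the methylene link drives the step remains open, and an unsubstituted benzyl, a methyl or a longer phenylalkyl chain at this carbon would separate these parts. Also open, from the compounds shown here alone, is whether the chloro and fluoro differences on the sulfonamide aryl ring persist without the 4-fluorobenzyl.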